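A few compounds are considered here, and "the series" means these few. Any claim that something is new, unique, unknown or untested is made for them only; others in the source may bear on it.

In a functional assay on U-87MG ATCC cells for antiproliferative activity against U-87 MG (Homo sapiens), with a stated time of 5 days (a lower number here means that less compound is needed, a higher number that more compound is needed for the effect), compound 1 (`Nc1nc2cc(-c3nn(CC4CCCO4)c4ncnc(N)c34)ccc2o1`) gives 100 nM. Within the data shown here, compound 2 (`CCOC(Cn1nc(-c2ccc3oc(N)nc3c2)c2c(N)ncnc21)OCC`) gives 100 nM, which leaves the two level as the highest of the three numbers so far. Compound 3 (`Nc1nc2cc(-c3nn(CC4CCCC4)c4ncnc(N)c34)ccc2o1`) gives 13 nM, the lowest of the three.

The next compound is compound 4 (`Nc1nc2cc(-c3nn(C[C@@H]4CCCO4)c4ncnc(N)c34)ccc2o1`). Its difference from compound 1 is as follows: the two compounds have the same atoms and bonds; at least one stereo element is drawn with a configuration in one of them and without one in the other: 1 of 1 stereo elements differ; a stereocentre at a saturated ring carbon is drawn without a configuration in compound 1 and S in compound 4. A stereocentre at a saturated ring carbon is thus drawn without a configuration in compound 1 and S in compound 4.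

Among the measured compounds shown here, no measured pair differs in configuration alone, so the evidence is indirect. With diethoxymethyl in place of oxolan-2-yl, the data show no change at the digits printed from compound 1 to compound 2 (within the scatter). With cyclopentyl in place of oxolan-2-yl, they show a 7.7-fold lower number from compound 1 to compound 3 (0.89 log units; beyond the scatter), a modest step. Both steps replace the whole group, whereas compound 4 keeps every atom and bond of compound 1. The step to compound 4 should therefore be smaller than the modest one to compound 3, probably within the scatter. Its direction is open, with a slight lean towards a lower number. The expected step is a 1.3-fold lower number from compound 1 to compound 4 (0.10 log units; within the scatter). Compound 4 is estimated at 80 nM, with an expected range of 30 nM to 220 nM.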

Compound 4, half-maximal effective concentration: 100 nM
Compound 4: middle estimate off by 1.3-fold (0.10 log units), on the low side, within the range that was stated.
By their numbers in this assay, from the lowest: compound 3; then compounds 1, 2 and 4 (each within the scatter of the next).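

In this assay, the S form of the oxolan-2-yl group stands level with the drawing that has no defined configuration: no change at the digits printed from compound 1 to compound 4 (within the scatter). The gap to the cyclopentyl group holds with a defined configuration in place, a 7.7-fold higher number from compound 3 to compound 4 (0.89 log units; beyond the scatter), and the S form also stays level with the diethoxymethyl group, no change at the digits printed from compound 2 to compound 4 (within the scatter), so the earlier reading of this position no longer rests only on an undefined drawing. The only thing separating the two oxolan-2-yl entries is how they are drawn: the fact that one of compounds 1 and 4 is drawn with a defined configuration and the other without, at the place where they differ.

As far as these compounds go, whether the R form of the oxolan-2-yl group would give the same number stays open, as does the make-up of the material behind the undefined drawing of compound 1, so no effect of configuration can be stated either way. Among these compounds, also open is how a saturated ring carrying an amine, or a longer chain ending in the cyclopentyl group, would compare with compound 3 at 13 nM, the one number so far beyond the scatter of the others.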